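The source may hold more compounds than are shown below. What is called first, only, known or untested is meant among the compounds shown, and "the series" means these compounds.

Working notes on the series. Compound 1 `CCCC(=O)c1ccc(OCCCCOc2ccc(F)c(C(=O)O)c2)c(C)c1O`, compound 2 `Cc1c(OCCCCOc2ccc(C(=O)O)cc2Cl)ccc(C(=O)CC2CCCC2)c1O`, compound 3 `Cc1c(OCCCCOc2ccc(C(=O)O)cc2)ccc(C(=O)CC2CCCC2)c1C` and compound 4 `COc1ccc(C(=O)O)cc1OCCCCOc1ccc(C(=O)CC2CCCC2)c(O)c1C` share one core, differing in the aryl group on the distal ether oxygen and in the substituent on the phenol ring of the core. In an assay on HEK293 cells for positive allosteric modulation of metabotropic glutamate receptor 2 (Rattus norvegicus), read by thallium flux, with a stated time of 2.5 min (a lower number here means that less compound is needed, a higher number that more compound is needed for the effect), compound 1 gives 74 nM. In this assay compound 2 gives 237 nM, the higher of the two numbers in hand; the gap between compound 2 and compound 1 is beyond the scatter. Going by the values given here, for compound 3 the result in this assay is "not determined" (no result reported), so only two numbers are available.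

The step to compound 4 is 5-carboxy-2-methoxyphenyl in place of 4-carboxy-2-chlorophenyl on an oxygen on a saturated carbon. Among the compounds with values here, no measured pair isolates this change, and the two numbers in hand come from compounds that differ in more than one place, so the direction is uncertain. The working expectation is a modest rise in the number, since the carboxy group of compound 4 stands in a new position relative to the ether; the step from compound 2 to compound 4 is estimated at a 1.7-fold higher number from compound 2 to compound 4 (0.23 log units; within the scatter). Compound 4 is expected to give 400 nM, with a range from 120 nM to 1300 nM.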

Compound 4, half-maximal effective concentration: 425 nM
Estimate against measurement, compound 4: 1.1-fold (0.03 log units) below; measured number inside the range.
By their numbers in this assay, from the lowest: compound 1; then compounds 2 and 4 (each within the scatter of the next).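

In this assay, going by these compounds alone, the exchange of 4-carboxy-2-chlorophenyl for 5-carboxy-2-methoxyphenyl on an oxygen on a saturated carbon gives a 1.8-fold higher number from compound 2 to compound 4 (0.25 log units; within the scatter) and provides the first step that differs in one place. This position therefore accepts a different aryl group, with the carboxy group placed differently and methoxy in place of chloro, without a change that can be read beyond the scatter. No supporting measurement bears on why this step is so small.

Because the carboxy placement and the methoxy-for-chloro exchange travel together in this single step, their separate contributions stay unresolved. Also open, from the compounds shown here alone, is how this position would respond to a tetrazole in place of the carboxy group, or to an ethoxy group in place of the methoxy group.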